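Three measured tails and a fourth one awaiting its number

A few compounds are considered here, and "the series" means these few. Any claim that something is new, unique, unknown or untested is made for them only; others in the source may bear on it.

Three compounds share one core and differ only in the tail attached through an oxygen on an aromatic ring. Compound 1 `CCCCCCCCCCCOc1ccccc1CCC(=O)OCCCOP(=O)(O)OC[C@H](N)C(=O)O` gives 14.6% in an assay on cells for agonist activity at probable G-protein coupled receptor 34 (Mus musculus), with a stated time of 1 h; a lower number here means a smaller maximal response, a higher number a larger maximal response. Compound 2 `N[C@@H](COP(=O)(O)OCCCOC(=O)CCc1ccccc1OCCCCCCOc1ccccc1)C(=O)O` gives 20.7% in this assay, and the step of a number 6.1 percentage points higher from compound 1 to compound 2 (within the scatter) stays within the scatter. Compound 3 `Cc1ccccc1Oc1cccc(COc2ccccc2CCC(=O)OCCCOP(=O)(O)OC[C@H](N)C(=O)O)c1` gives 20.3% in this assay; among the three numbers it stands second highest, nearest to compound 2 and furthest from compound 1, with both gaps within the scatter. All three maximal responses therefore sit in one narrow band, and none of the compounds can be called the strongest or the weakest.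

Compound 4 `N[C@@H](COP(=O)(O)OCCCOC(=O)CCc1ccccc1OCc1cccc(Oc2ccc(Br)cc2)c1)C(=O)O` has not yet been measured. It differs from compound 3 in one place: 4-bromophenyl in place of 2-methylphenyl on an oxygen on an aromatic ring. For the measured compounds named here, no measured step covers this exact change. Going by the values given here, the only measured step, a number 6.1 percentage points higher from compound 1 to compound 2 (within the scatter), altered a different part of the tail and stayed within the scatter, and the three measured tails, though varied, produced numbers close together. On that basis compound 4 is expected to give a maximal response similar to the others. Compound 4 is estimated at 20%, with a range from 11% to 31%. The step of a number 0.3 percentage points lower from compound 3 to compound 4 (within the scatter) is expected to lie within the scatter.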

Compound 4, largest response reached (Emax), in percent of the reference or control that the assay uses: 17.7%
The estimate for compound 4 lay 2.3 percentage points above the measured number; low and high end bracket the measured number.
By their numbers in this assay, from the lowest: compounds 1, 4, 3 and 2 (each within the scatter of the next).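

Placing 4-bromophenyl in place of 2-methylphenyl on an oxygen on an aromatic ring gives a number 2.6 percentage points lower from compound 3 to compound 4 (within the scatter) in this assay and is the first measured change at this place in the tail. Both groups have 7 heavy atoms and one six-membered aromatic ring of carbon only, so the swap brings a bromine into the measured set while keeping those counts, and the maximal response does not tell the two groups apart. No other measurement shown here bears on what lies behind this result.

The step also alters two things at once, the substituent on the ring and its number in the group's name, so the separate share of each cannot be read from it; 4-methylphenyl and 2-bromophenyl at this place would pull the two apart. Going by these compounds, whether a ring carrying an amine or a carboxylic acid on that same oxygen would stay in the same narrow band also remains open.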